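The compounds below may be only part of what the source reports. "The series", "measured", "known", "first", "only" and "open" are said of these compounds alone.

Measured so far:
- compound 1 `COCCNc1nc(N)nc2ccn(Cc3ccccn3)c12`: > 24000 nM (a limit)
- compound 2 `Cc1nnc(CNc2nc(N)nc3ccn(Cc4ccccn4)c23)o1`: > 24000 nM (a limit)

In an ADME assay on HEK293 cells (Homo sapiens) for cytotoxicity, read by ATP content, with a stated time of 6 h (a lower number here means that less compound is tolerated, a higher number that more compound is tolerated), compound 2 gives > 24000 nM, which is a limit of the assay and not a number. The evidence so far amounts to the limit of > 24000 nM in this assay, at which 2 of the 2 values shown sit.

The next change leads to compound 3 `Cc1coc(CNc2nc(N)nc3ccn(Cc4ccccn4)c23)n1`: 4-methyl-1,3-oxazol-2-yl in place of 5-methyl-1,3,4-oxadiazol-2-yl on a saturated chain carbon bound to a nitrogen on an aromatic ring. Within the data shown here, only one measured step bears on it. This is a step that the two limits leave unreadable from compound 1 to compound 2, with 5-methyl-1,3,4-oxadiazol-2-yl in place of methoxymethyl at the same place. That step has no readable size, so it gives no magnitude to carry over to the new change, and it gives no direction either.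

The expectation therefore rests on both measured compounds sitting at the same limit in this assay, and no step beyond the scatter is expected. The estimated step is a number no higher from compound 2 to compound 3 (the limit leaves the size open). A report of compound 3 as a limit again is the likeliest outcome. The expected value for compound 3 is 24000 nM, with an estimated range from 12000 nM to 48000 nM.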

Compound 3, half-maximal cytotoxic concentration: > 24000 nM
Compound 3: a limit, no number (the forecaster's own chance of this, stated with the estimate: 85%); the middle value lies on the limit itself.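

In this assay compound 3 gives > 24000 nM, which is a limit of the assay and not a number. The steps among compound 1, compound 2 and compound 3 therefore cannot be read, and the record stands thus: the limit of > 24000 nM in this assay, at which 3 of the 3 values shown sit.

From the compounds shown here alone, whether these three compounds differ at all in this assay remains open.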